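Benzyl-triazole dithiocarbamates: fluoro to methoxy on the benzyl ring

The compounds below may be only part of what the source reports. "The series", "measured", "known", "first", "only" and "open" are said of these compounds alone.

Within the data shown here, compound 2 `O=C(OCc1ccccc1)N1CCN(C(=S)SCc2cn(Cc3ccc(F)cc3)nn2)CC1` is the one member of the series with a reported number: in a functional assay on MGC-803 cells (Homo sapiens) for inhibition, read by MTT assay, with a stated time of 72 h (on this read-out lower numbers stand for stronger inhibition and higher numbers for weaker inhibition), compound 2 gives 17600 nM. Compound 1 `COc1ccc(Cn2cc(CSC(=S)N3CCNCC3)nn2)cc1` has no number; in this assay the entry for compound 1 reads "not determined" (no result reported). Compound 3 `COc1ccc(Cn2cc(CSC(=S)N3CCN(C(=O)OCc4ccccc4)CC3)nn2)cc1` is yet to be measured in this assay. The change from compound 2 to compound 3 is methoxy in place of fluoro on an aromatic carbon. Among the measured compounds shown here, no measured pair shows this change, so its effect is not known from the data. With nothing pointing either way, the expected step from compound 2 to compound 3 in this assay is a 1.2-fold lower number from compound 2 to compound 3 (0.07 log units; within the scatter), a step that is expected to stay within the usual scatter. Compound 3 is therefore estimated to give about 15000 nM in this assay, with a range expected from 6000 nM to 40000 nM.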

Compound 3, half-maximal inhibitory concentration: 23800 nM
Beside the measured number, compound 3's estimate is 1.6-fold (0.20 log units) below it; measured number inside the range.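

The 4-fluorobenzyl to 4-methoxybenzyl exchange now has its first measured pair: in this assay the result is a 1.4-fold higher number from compound 2 to compound 3 (0.13 log units; within the scatter) and so gives no sign that this position tells methoxy from fluoro. The additional heavy atom and the hydrogen-bond acceptor that methoxy brings leave the number within the usual scatter of this assay, on a single pair. Nothing measured on these compounds offers an explanation for this result.

Among these compounds, only one exchange at this position can be read, so it remains open whether an amine or a carboxylic acid in the same place would move the number beyond the scatter. As far as these compounds go, compound 1 has no number, so its step to compound 3 cannot be read, and the contribution of the benzyl carbamate remains unknown.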